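Aryl variant on the shared core: compound 4

The source may hold more compounds than are shown below. What is called first, only, known or untested is meant among the compounds shown, and "the series" means these compounds.

Measured compounds:
Compound 1 `C/C(=C\CC/C(C)=C/CC[C@@H]1[C@@]2(C)CCC(=O)C(C)(C)[C@H]2CC[C@@]1(C)O)CC/C=C(\C)C(=O)OCc1cn(-c2cccc(O)c2)nn1`: 42800 nM.
Compound 2 `C/C(=C\CC/C(C)=C/CC[C@@H]1[C@@]2(C)CCC(=O)C(C)(C)[C@H]2CC[C@@]1(C)O)CC/C=C(\C)C(=O)OCc1cn(-c2ccccc2)nn1`: a limit, > 150000 nM.
Compound 3 `C/C(=C\CC/C(C)=C/CC[C@@H]1[C@@]2(C)CCC(=O)C(C)(C)[C@H]2CC[C@@]1(C)O)CC/C=C(\C)C(=O)OCc1cn(-c2ccccc2[N+](=O)[O-])nn1`: a limit, > 150000 nM.

Going by the values given here, in a functional assay on A549 cells (Homo sapiens) for antiproliferative activity, read by MTT assay, with a stated time of 48 h (a higher number here means a weaker inhibitor, a lower number a stronger inhibitor), compound 1 gives 42800 nM, the only number among the three values shown. For compound 2 the assay reports only a limit, > 150000 nM. For compound 3 the assay likewise reports only a limit, > 150000 nM. Compound 1 therefore stands alone as a number; the other two values sit at the limit of > 150000 nM in this assay, at which 2 of the 3 values shown sit.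

The steps: an at least 3.5-fold higher number from compound 1 to compound 2 (0.54 log units; beyond the scatter); an at least 3.5-fold higher number from compound 1 to compound 3 (0.54 log units; beyond the scatter); a step that the two limits leave unreadable from compound 2 to compound 3.

Compound 4 `COc1ccccc1-n1cc(COC(=O)/C(C)=C/CC/C(C)=C/CC/C(C)=C/CC[C@@H]2[C@@]3(C)CCC(=O)C(C)(C)[C@H]3CC[C@@]2(C)O)nn1` is not yet measured. Change from compound 1: 2-methoxyphenyl in place of 3-hydroxyphenyl on an aromatic nitrogen. Both measured steps from compound 1 bear on it: the hydroxy is lost, as in an at least 3.5-fold higher number from compound 1 to compound 2 (0.54 log units; beyond the scatter), and a different aryl carries a group two ring bonds from the ring nitrogen, as in an at least 3.5-fold higher number from compound 1 to compound 3 (0.54 log units; beyond the scatter). Both reached the limit, so a step to a higher number, probably to a limit, is expected: a 3.5-fold higher number from compound 1 to compound 4 (0.54 log units; beyond the scatter). Compound 4 is estimated at 150000 nM, with a range of 50000 nM to 400000 nM.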

Compound 4, half-maximal inhibitory concentration: > 150000 nM
Compound 4: no number, only a limit (the forecaster's own chance of this, stated with the estimate: 65%); the middle value lies on the limit itself.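

In this assay, 2-methoxyphenyl in place of 3-hydroxyphenyl gives an at least 3.5-fold higher number from compound 1 to compound 4 (0.54 log units; beyond the scatter), and the size of this step is open-ended. The entering group keeps an oxygen and the hydrogen-bond acceptor count of the leaving group but has no hydrogen-bond donor, so an aryl oxygen alone does not bring back a measured value; among the compounds shown, only compound 1 carries a hydroxy and gives a number. The steps among compounds 2, 3 and 4 cannot be read, and these compounds cannot be ranked: the limit of > 150000 nM in this assay, at which 3 of the 4 values shown sit.

Compound 4 changes both the oxygen substituent and its place on the aryl ring, so the two effects remain unseparated. Also open, on these data alone, is whether an amine or a carboxylic acid in place of the hydroxy would retain a measurable value.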